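A few compounds are considered here, and "the series" means these few. Any claim that something is new, unique, unknown or untested is made for them only; others in the source may bear on it.

Measured in an ADME assay on MRC5 cells (Homo sapiens) for cytotoxicity, read by fluorescence and resazurin assay, with a stated time of 3 days (on this read-out higher numbers stand for weaker inhibition and lower numbers for stronger inhibition), so far
Compound 1 `Cc1cn(C2CCN(Cc3cccc(Oc4cc(Cl)cc(Cl)c4)c3)CC2)c(=O)[nH]c1=O` gives 6730 nM
Compound 2 `Cc1cn(C2CCN(Cc3cncc(Oc4cc(Cl)cc(Cl)c4)c3)CC2)c(=O)[nH]c1=O` gives > 64000 nM as an assay limit
Compound 3 `Cc1cn(C2CCN(Cc3cccc(Oc4cccc(Cl)c4)n3)CC2)c(=O)[nH]c1=O` gives > 64000 nM as an assay limit

Within the data shown here, compound 1 holds the only number in the set. Compound 2 and compound 3 give limits, not numbers (the limit of > 64000 nM in this assay, at which 2 of the 3 values shown sit). Compound 4 `Cc1cn(C2CCN(Cc3cccc(Oc4ccccn4)c3)CC2)c(=O)[nH]c1=O` carries pyridin-2-yl in place of 3,5-dichlorophenyl on an oxygen on an aromatic ring. Among the measured compounds shown here, no step between measured neighbours is available. A step toward weaker inhibition in this assay, beyond the scatter, is expected. For the measured compounds named here, that expectation rests on compound 1 at 6730 nM being the sole compound with a measured number. The estimated step runs a 7.4-fold higher number from compound 1 to compound 4 (0.87 log units; beyond the scatter) and may end in a limit reading. For compound 4 the expected value is 50000 nM with an estimated range from 20000 nM to 120000 nM in this estimate.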

Compound 4, half-maximal inhibitory concentration: > 64000 nM
Compound 4: no number, only a limit; the forecaster's own chance of this, stated with the estimate: 50%; middle value at least 1.2-fold (0.10 log units) away from the limit.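

In this assay, among these compounds, this position gives the series its only single-place comparison: pyridin-2-yl in place of 3,5-dichlorophenyl on an oxygen on an aromatic ring is an at least 9.5-fold higher number from compound 1 to compound 4 (0.97 log units; beyond the scatter). Compound 4 gives > 64000 nM, which is a limit of the assay and not a number. The step therefore has a lower bound but no measured size: the limit of > 64000 nM in this assay, at which 3 of the 4 values shown sit.

The compounds shown do not separate removal of the two chlorines from entry of the ring nitrogen. Going by these compounds, how an unsubstituted phenyl on this oxygen would read remains open.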